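The source may hold more compounds than are shown below. What is called first, only, known or untested is meant among the compounds shown, and "the series" means these compounds.

In an ADME assay on T29 cells (Homo sapiens) for cytotoxicity, read by sulforhodamine B assay, with a stated time of 3 days (on this read-out higher numbers stand for weaker inhibition and lower numbers for stronger inhibition), compound 2 `OCc1cn(Cc2ccc(Cl)cc2)c2ccccc12` gives > 31600 nM as a limit and not a number. Compound 3 `COc1ccc(Cn2cc(CO)c3ccccc32)cc1` gives > 31600 nM as a limit too. Compound 1 `O=Cc1cn(Cc2ccc(Cl)cc2)c2cc(F)ccc12`, which already carries the fluoro, gives > 31600 nM as a limit as well. Compound 2 thus stands with the others at the limit of > 31600 nM in this assay, at which 3 of the 3 values shown sit, in this series. Compound 4 `OCc1cn(Cc2ccc(Cl)cc2)c2cc(F)ccc12` differs from compound 2 by fluoro in place of hydrogen on an aromatic carbon is the whole change. Going by the values given here, the one measured step, a step that the two limits leave unreadable from compound 2 to compound 3, gives no size to carry over, so no shift beyond the scatter is expected in this assay here. The expected step is a number no higher from compound 2 to compound 4 (the limit leaves the size open) and it is estimated to stay within the scatter. Compound 4 is estimated at 31600 nM with an expected range from 15000 nM to 60000 nM on this read-out.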

Compound 4, half-maximal inhibitory concentration: > 31600 nM
Compound 4: only a limit was reported; the forecaster's own chance of this, stated with the estimate: 85%; the middle value sits exactly at the limit.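

In this assay compound 4 gives > 31600 nM, a limit and not a number. The steps to compound 4 from compound 2 and from compound 1 cannot be read. The compounds shown leave open whether any of these changes shifts the read-out at all: the limit of > 31600 nM in this assay, at which 4 of the 4 values shown sit.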